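Acid to acylhydrazone: what is expected of compound 4

The source may hold more compounds than are shown below. What is called first, only, known or untested is meant among the compounds shown, and "the series" means these compounds.

Measured so far:
compound 1, `Cc1n[nH]c2c1C(c1ccc(N(C)C)cc1)C(C(N)=O)=C(N)N2`, gives 4550 nM in a functional assay on MCF7 cells (Homo sapiens) for cytotoxicity, read by MTT assay, with a stated time of 48 h; on this read-out higher numbers stand for weaker inhibition and lower numbers for stronger inhibition
compound 2, `Cc1n[nH]c2c1C(c1ccc(N(C)C)cc1)C(C(=O)O)=C(N)N2`, gives 22000 nM in this assay
compound 3, `Cc1n[nH]c2c1C(c1ccc(N(C)C)cc1)C(C(=O)N/N=C1/C(=O)Nc3ccccc31)=C(N)N2`, gives 59100 nM in this assay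

Compound 2 stands second highest of the three numbers: the step of a 4.8-fold higher number from compound 1 to compound 2 (0.68 log units; beyond the scatter) sets it beyond the scatter from compound 1, and compound 3 lies higher still, also beyond the scatter. Compound 4, `Cc1n[nH]c2c1C(c1ccc(N(C)C)cc1)C(C(=O)N/N=C/c1ccc(Cl)cc1)=C(N)N2`, differs from compound 2 by a group of 10 heavy atoms (7 carbon, 2 nitrogen, 1 chlorine; one six-membered aromatic ring of carbon only) in place of one oxygen atom, on a carbonyl carbon. The step that bears on this is a 13-fold higher number from compound 1 to compound 3 (1.11 log units; beyond the scatter), in which a group of similar size entered on the amide-type nitrogen of compound 1. Since compound 3 already sits above compound 2, a modest rise is expected, a 2.0-fold higher number from compound 2 to compound 4 (0.31 log units; beyond the scatter). The estimate for compound 4 is 45000 nM, within 15000 nM to 130000 nM.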

Compound 4, half-maximal inhibitory concentration: 25200 nM
Compound 4: middle estimate off by 1.8-fold (0.25 log units), on the high side; low and high end bracket the measured number.
By their numbers in this assay, from the lowest: compound 1; then compounds 2 and 4 (each within the scatter of the next); then compound 3.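

In this assay, exchanging the hydroxy on the carbonyl carbon for the far larger group of compound 4 leaves the two compounds indistinguishable (a 1.1-fold higher number from compound 2 to compound 4 (0.06 log units; within the scatter)), so the acid holds no measurable place of its own here. Both groups on the amide-type nitrogen give a higher number than the unsubstituted amide (a 5.5-fold higher number from compound 1 to compound 4 (0.74 log units; beyond the scatter)), yet the identity of the group still counts (a 2.3-fold lower number from compound 3 to compound 4 (0.37 log units; beyond the scatter)). No measurement given explains these steps. Open, on these data alone, is whether a methyl on the amide-type nitrogen, or a methoxy in place of the chlorine, would stay near compound 1.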